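Swapping a Cycloheptyl for a Naphthalenyl Group

A few compounds are considered here, and "the series" means these few. Any claim that something is new, unique, unknown or untested is made for them only; others in the source may bear on it.

Of the compounds shown here, two from this series have been measured. Compound 1 `Nc1scc(CN2CCN(c3ccc(F)cc3Cl)CC2)c1C(=O)c1ccc(Cl)cc1` and compound 2 `Nc1scc(CN2CCN(C3CCCCCC3)CC2)c1C(=O)c1ccc(Cl)cc1` share a common core and differ only in the group on an amine nitrogen in a ring. In a functional assay on CHO cells with adenosine receptor A1 (Homo sapiens) as the target, read by cAMP accumulation and immunoassay, with a stated time of 6 min, tested at 1 uM (a higher number here means a weaker effect of the compound at the concentration tested, a lower number a stronger effect), compound 1 gives -39% and compound 2 gives 3.7%. The measured step of a number 42.7 percentage points higher from compound 1 to compound 2 (beyond the scatter) is the only one available, and it shows that replacing the aromatic group with a saturated ring moved the read-out well beyond the usual scatter. On the numbers shown, compound 2 stands highest, with compound 1 the nearest neighbour.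

Compound 3 `Nc1scc(CN2CCN(c3cccc4ccccc34)CC2)c1C(=O)c1ccc(Cl)cc1` is not yet measured. It differs from compound 2 in one place: naphthalen-1-yl in place of cycloheptyl on an amine nitrogen in a ring. This change brings an aromatic group back onto the ring nitrogen, which is the reverse of the kind of change seen from compound 1 to compound 2. Because that step a number 42.7 percentage points higher from compound 1 to compound 2 (beyond the scatter) was large, a step of roughly comparable size in the opposite direction, toward a lower number in this assay, is expected for compound 3, as a number 23.7 percentage points lower from compound 2 to compound 3 (beyond the scatter). Compound 3 is therefore estimated at -20%, with a likely range from -50% to 15%.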

Compound 3, a percentage reported as activity, at one concentration (the size of the read-out at that concentration, not a potency): 2.9%
For compound 3 the middle estimate is 22.9 percentage points below the measured one; the measured number falls inside the stated range.
By their numbers in this assay, from the lowest: compound 1; then compounds 3 and 2 (each within the scatter of the next).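

In this assay, the step of a number 0.8 percentage points lower from compound 2 to compound 3 (within the scatter) shows that putting an aromatic group on this ring nitrogen does not by itself bring the read-out close to that of compound 1, since naphthalen-1-yl, with its two six-membered aromatic rings, and cycloheptyl, with its seven-membered non-aromatic ring, cannot be told apart here. The step of a number 41.9 percentage points higher from compound 1 to compound 3 (beyond the scatter) shows that two aromatic groups at this one position can also give clearly different read-outs, so the earlier contrast cannot be reduced to aromatic against saturated, and among these three compounds 2-chloro-4-fluorophenyl alone gives the low number. Nothing available explains why this group differs from the other two.

As far as these compounds go, it remains open whether the low number of compound 1 depends on the chlorine, the fluorine or the phenyl ring itself, a question that an unsubstituted phenyl, a 2-chlorophenyl and a 4-fluorophenyl at this nitrogen would help to answer. From the compounds shown here alone, it is also open how a small group such as methyl would behave here, and these single-concentration read-outs say nothing about potency.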